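Chloro in Place of Hydrogen on Compound 1

The compounds below may be only part of what the source reports. "The series", "measured", "known", "first", "only" and "open" are said of these compounds alone.

Among the compounds with values here, in a functional assay on KKU-M156 cells (Homo sapiens) for cytotoxicity, read by MTT assay (on this read-out lower numbers stand for stronger inhibition and higher numbers for weaker inhibition), compound 1 (`Cc1cc(O)c(C=O)c2c1C(=O)Oc1c(O)c3c(c(C)c1O2)C(=O)CC(C)(C)O3`) gives 2.9 ug/mL and holds the lowest of the two numbers so far. Compound 2 (`Cc1cc(O)c(C=O)c2c1C(=O)Oc1c(cc3c(c1C)C(=O)CC(C)(C)O3)O2`) reads higher at 15.7 ug/mL and that gap lies beyond the usual scatter. Compound 3 (`Cc1c2c(c(O)c3c1C(=O)CC(C)(C)O3)OC(=O)c1c(C)c(Cl)c(O)c(C=O)c1O2`) is compound 1 with chloro in place of hydrogen on an aromatic carbon, ortho to a hydroxy group and ortho to a methyl group. Within the data shown here, no measured pair shows what such a change does, so the expectation rests on compound 1 at 2.9 ug/mL alone. An estimated step of a 1.2-fold lower number from compound 1 to compound 3 (0.08 log units; within the scatter) is expected to stay within the scatter, with no clear change in either direction. Compound 3 is expected to give 2.4 ug/mL in this assay with values between 0.9 ug/mL and 6.5 ug/mL as the estimated range.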

Compound 3, half-maximal inhibitory concentration: 5.36 ug/mL
Estimate against measurement, compound 3: 2.2-fold (0.35 log units) below; the measured number falls inside the stated range.
By their numbers in this assay, from the lowest: compounds 1 and 3 (each within the scatter of the next); then compound 2.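

In this assay, chloro in place of hydrogen on the aromatic carbon ortho to a hydroxy group and ortho to a methyl group gives a 1.8-fold higher number from compound 1 to compound 3 (0.27 log units; within the scatter). This position therefore carries a chlorine atom with no change that can be told from the scatter, which neither compound 1 nor compound 2 could show alone. Nothing measured on the chloro group or on this position bears on the result, and the reason for it stays unknown.

The compounds shown hold only hydrogen and chloro at this carbon, so what an amine, a methoxy group or a carboxylic acid would do there remains open. Also open, as far as these compounds go, is whether chloro at this carbon would give a step of like size on compound 2.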